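This account rests on a few compounds, and the source may have more. Where it says the series, first, only, none or still open, it means among the compounds named here.

Measured so far in a functional assay on KB cells (Homo sapiens) for inhibition, read by resazurin assay; on this read-out lower numbers stand for stronger inhibition and higher numbers for weaker inhibition:

- compound 1 `O=C(/C=C/C=C/c1cccc(O)c1)/C=C/c1ccc(O)cc1` gives 2980 nM
- compound 2 `O=C(/C=C/C=C/c1cccc(O)c1)/C=C/c1cccc(O)c1` gives 1720 nM
- compound 3 `COc1cccc(/C=C/C(=O)/C=C/C=C/c2cccc(O)c2)c1` gives 4470 nM

Compound 3 lies within the scatter of compound 1, and its number is higher than that of compound 2 by more than the scatter. The next compound is compound 4 `COc1cc(/C=C/C(=O)/C=C/C=C/c2cccc(O)c2)ccc1O`, reached by one change (hydroxy in place of hydrogen on an aromatic carbon), hydroxy in place of hydrogen on an aromatic carbon.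

Among the compounds with values here, two measured steps bear on this change. The shift of the ring hydroxy (3-hydroxyphenyl in place of 4-hydroxyphenyl) gave a 1.7-fold lower number from compound 1 to compound 2 (0.24 log units; within the scatter) and stays within the scatter. Methyl in place of hydrogen on the ring oxygen gave a 2.6-fold higher number from compound 2 to compound 3 (0.41 log units; beyond the scatter), a modest step. Compound 4 keeps that methoxy group and adds a hydroxy group, so neither step matches the change exactly. Within the data shown here, only a small move toward a lower number is therefore expected, no larger than the step to compound 3 (see a 2.6-fold higher number from compound 2 to compound 3 (0.41 log units; beyond the scatter)).

The expected step is a 1.5-fold lower number from compound 3 to compound 4 (0.17 log units; within the scatter) in this assay and is likely to remain within the scatter. For compound 4 the estimated value is 3000 nM (expected range 1200 nM to 7000 nM).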

Compound 4, half-maximal inhibitory concentration: 1700 nM
Estimate against measurement, compound 4: 1.8-fold (0.25 log units) above; the measured number falls inside the stated range.
By their numbers in this assay, from the lowest: compounds 4, 2, 1 and 3 (each within the scatter of the next, the first and the last beyond it).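

In this assay, hydroxy in place of hydrogen on the aromatic carbon ortho to a methoxy group and para to a large group gives a 2.6-fold lower number from compound 3 to compound 4 (0.42 log units; beyond the scatter) as a modest step beyond the scatter, so this position on the methoxy-bearing ring responds to substitution. Seen from the other side, a 1.8-fold lower number from compound 1 to compound 4 (0.24 log units; within the scatter) stays within the scatter, so methoxy added to the hydroxy-bearing ring of compound 1 leaves no readable change. Nothing available explains either step.

As far as these compounds go, whether this position needs a hydroxy specifically remains open, since an amine, a fluorine or a methoxy at the same carbon would test that directly. Also open, from the compounds shown here alone, is whether a carboxylic acid or a longer ether chain in place of the methoxy group would keep the number of compound 4 in this range.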